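A few compounds are considered here, and "the series" means these few. Any claim that something is new, unique, unknown or untested is made for them only; others in the source may bear on it.

Measured so far:
- compound 1, `CS(=O)(=O)Nc1ccc([N+](=O)[O-])cc1OCc1ccc(F)cc1`, gives 580 nM in an assay on SK-BR-3 cells for inhibition of Aromatase (Homo sapiens); a lower number here means a stronger inhibitor, a higher number a weaker inhibitor
- compound 2, `O=C(Nc1ccc([N+](=O)[O-])cc1OCc1ccccc1)C1CCCCC1`, gives only a limit of > 25000 nM in this assay

Of the two compounds measured, only compound 1 has a definite number in this assay. Compound 2 stands at the limit of this assay, where (the limit of > 25000 nM in this assay, at which 1 of the 2 values shown sits); its reading is a limit and not a number, so how far beyond it the true value lies is not known. Compound 3, `N#Cc1ccc(C(=O)Nc2ccc([N+](=O)[O-])cc2OCc2ccccc2)cc1`, has not yet been measured. It differs from compound 2 in a single place: 4-cyanophenyl in place of cyclohexyl on a carbonyl carbon. Among the measured compounds shown here, no measured pair of compounds shows what this kind of change does in this assay, so the size of the step is open. A gain in potency is expected, with the step from compound 2 to compound 3 estimated at an at least 4.1-fold lower number from compound 2 to compound 3 (0.61 log units; beyond the scatter), though given where compound 2 sits, a further limit cannot be excluded. Compound 3 is therefore expected to give about 6000 nM, within a range from 800 nM to 30000 nM.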

Compound 3, half-maximal inhibitory concentration: > 25000 nM
Compound 3: only a limit was reported (the forecaster's own chance of this, stated with the estimate: 35%); middle value at least 4.1-fold (0.61 log units) from the limit.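

Among the compounds shown here, compound 2 and compound 3 both sit at a limit of this assay, and no step between them can be read. The compounds shown leave open how far either lies beyond that limit, and whether 4-cyanophenyl in place of cyclohexyl on a carbonyl carbon changes anything.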